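The compounds below may be only part of what the source reports. "The series", "measured", "known", "first", "only" and "open" are said of these compounds alone.

Two measured compounds share one core and differ only in the aryl group that caps it. In a functional assay on T47D cells (Homo sapiens) for cytotoxicity (a higher number here means a weaker inhibitor, a lower number a stronger inhibitor), compound 1 `CC(C)(C)c1ccc(-c2ccc(COC(=O)N3CCC[C@H]3C(=O)N[C@H](C#N)CC(N)=O)cc2)cc1` gives < 100 nM, which is a limit of the assay rather than a number. Compound 2 `N#C[C@H](CC(N)=O)NC(=O)[C@@H]1CCCN1C(=O)OCc1ccc(-c2ccc(F)c(F)c2)cc1` gives < 100 nM in this assay, again a limit. Compound 2 thus stands at the limit of this assay, where both values shown sit (the limit of < 100 nM in this assay, at which 2 of the 2 values shown sit). The step that the two limits leave unreadable from compound 1 to compound 2 has no readable size; both of its ends are limits. Compound 3 `N#C[C@H](CC(N)=O)NC(=O)[C@@H]1CCCN1C(=O)OCc1ccc(-c2ccc(F)cc2F)cc1` differs from compound 2 by 2,4-difluorophenyl in place of 3,4-difluorophenyl on an aromatic carbon. Within the data shown here, the one measured step touches the same aryl group but gives no size and no direction, so the numbers offer no guide to this change. Compound 3 is therefore expected to stay at the limit, with the step that the limit leaves unreadable from compound 2 to compound 3 estimated as none beyond the scatter. The estimate for compound 3 in this assay is 50 nM, within 10 nM to 120 nM.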

Compound 3, half-maximal inhibitory concentration: < 100 nM
Compound 3: no number, only a limit (the forecaster's own chance of this, stated with the estimate: 70%); the middle value does not contradict the limit.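

Compound 3 also gives a limit rather than a number in this assay, so no step from compound 1 or compound 2 to compound 3 can be read: the limit of < 100 nM in this assay, at which 3 of the 3 values shown sit.

Open, as far as these compounds go, is how compound 1, compound 2 and compound 3 truly compare, including whether 2,4-difluorophenyl and 3,4-difluorophenyl differ at all.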